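A few compounds are considered here, and "the series" means these few. Any claim that something is new, unique, unknown or untested is made for them only; others in the source may bear on it.

Measured so far in a functional assay on MOLT-4 cells (Homo sapiens) for cytotoxicity, read by sulforhodamine B assay, with a stated time of 48 h; on this read-out higher numbers stand for weaker inhibition of growth and lower numbers for stronger inhibition of growth:
- compound 1 `ClCc1ccc(Cn2cnc3c(Cl)ncnc32)cc1`: 4780 nM
- compound 2 `ClCc1cccc(Cn2cnc3c(Cl)nc(Cl)nc32)c1`: 3380 nM

In this assay compound 1 gives 4780 nM, the highest of the two numbers shown. Compound 2 gives 3380 nM, and the gap between compound 2 and compound 1 lies within the usual scatter, so the two values show no order between them.

Compound 3 `ClCc1ccc(Cn2cnc3c(Cl)nc(Cl)nc32)cc1` has not yet been measured in this assay. It differs from compound 1 by chloro in place of hydrogen on an aromatic carbon. Among the measured compounds shown here, no step between measured compounds isolates this change, so the size of the effect is open; the only guide is that the two measured compounds, which share the chloromethylbenzyl arm and the core, sit within the scatter of each other. Compound 3 is therefore expected to show a step from compound 1 of a 1.4-fold lower number from compound 1 to compound 3 (0.14 log units; within the scatter), at most a small move toward stronger inhibition of growth. The estimate for compound 3 in this assay is 3500 nM, with a range of 1400 nM to 9000 nM.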

Compound 3, concentration for 50% growth inhibition: 10500 nM
Estimate against measurement, compound 3: 3.0-fold (0.48 log units) below, and the stated range ends below it.
By their numbers in this assay, from the lowest: compounds 2 and 1 (each within the scatter of the next); then compound 3.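

In this assay, putting chloro on the aromatic carbon between two ring nitrogen atoms gives a 2.2-fold higher number from compound 1 to compound 3 (0.34 log units; beyond the scatter) and moves the result toward weaker inhibition of growth, so this position responds to the change. Compound 2 also carries this chloro group but has the chloromethyl group placed differently on its chloromethylbenzyl arm; compound 2 gives 3380 nM and compound 3 gives 10500 nM, so the same chloro group goes with different numbers on the two arms. Nothing available explains the step.

With only one substituent shown at this carbon, it remains open whether the step is particular to chloro or would also appear with fluoro, methoxy or an amine. Among the compounds shown here, the single step also leaves open whether the same change would give a similar result on other arms.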